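Trifluoromethoxy for fluoro on a coumarin-series benzyl: cytotoxicity

The source may hold more compounds than are shown below. What is called first, only, known or untested is meant among the compounds shown, and "the series" means these compounds.

Compound 1 `Cc1c(Cc2ccccc2)c(=O)oc2cc(OCC(O)CNc3nc4ccccc4[nH]3)ccc12` reaches only a limit of the assay in an ADME assay on A549 cells (Homo sapiens) for cytotoxicity, read by CellTiter-Glo (a higher number here means that more compound is tolerated, a lower number that less compound is tolerated), reported as > 100000 nM. Within the data shown here, compound 2 `Cc1c(Cc2ccc(F)cc2)c(=O)oc2cc(OCC(O)CN3CCC(C(N)=O)CC3)ccc12` is the one compound here with a real number, giving 89300 nM in this assay. Compound 3 `Cc1c(Cc2ccc(OC(F)(F)F)cc2)c(=O)oc2cc(OCC(O)CN3CCC(C(N)=O)CC3)ccc12` differs from compound 2 in one place: trifluoromethoxy in place of fluoro on an aromatic carbon. Among the measured compounds shown here, no measured pair shows the effect of this change, so the step is expected to stay within the usual scatter, as a 1.3-fold lower number from compound 2 to compound 3 (0.11 log units; within the scatter). Compound 3 is therefore estimated at 70000 nM in this assay, with a range from 30000 nM to 150000 nM.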

Compound 3, half-maximal cytotoxic concentration: 68200 nM
Compound 3: the middle estimate sits 1.0-fold (0.01 log units) above what was measured; low and high end bracket the measured number.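

At this aromatic carbon, para to a large group, trifluoromethoxy takes the place of fluoro, 5 heavy atoms for 1, with a 1.3-fold lower number from compound 2 to compound 3 (0.12 log units; within the scatter) in this assay as the result. The earlier compounds shown here held no such pair, and this single pair does not tell the two groups apart. Both numbers stand close to the top of the range that the assay can read: the limit of > 100000 nM in this assay, at which 1 of the 3 values shown sits.

As far as these compounds go, whether an amine, a carboxylic acid or a longer chain at this carbon would read the same stays open. So does whether the change behaves alike on a different side chain.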